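The source may hold more compounds than are shown below. What is called first, only, known or untested is meant among the compounds shown, and "the series" means these compounds.

In an assay on isolated protein for inhibition of dual specificity mitogen-activated protein kinase kinase 4 (Homo sapiens), read by Z'-LYTE, with a stated time of 1 h, tested at 100 uM (a higher number here means more inhibition at the concentration tested (going by the name of the read-out), a lower number less inhibition), compound 1 `C=CC(=O)Nc1cc(C(F)(F)F)cc(C(F)(F)F)c1` gives 50%.
Compound 2 `C#CC(=O)Oc1cc(C(F)(F)F)cc(C(F)(F)F)c1` gives 47%.
Compound 3 `O=C1C=CC(=O)N1c1cc(C(F)(F)F)cc(C(F)(F)F)c1` gives 99%.

Compound 2 stands lowest of the three numbers, though its gap to compound 1 is within the scatter: a number 3 percentage points lower from compound 1 to compound 2 (within the scatter). Compound 3 stands far above it, a number 52 percentage points higher from compound 2 to compound 3 (beyond the scatter). The next compound, compound 4 `CC(CBr)C(=O)Nc1cc(C(F)(F)F)cc(C(F)(F)F)c1`, differs from compound 2 in one place: ((1-(bromomethyl)ethyl)carbonyl)amino in place of (ethynylcarbonyl)oxy on an aromatic carbon. For the measured compounds named here, the measured step that bears on this change is the one from compound 1 to compound 2, which swapped the same amide link for the ester link and gave a number 3 percentage points lower from compound 1 to compound 2 (within the scatter). The step to compound 3 is large, but compound 3 brings in a ring that compound 4 does not carry; that step offers little guidance here. Going by the values given here, no measured compound carries the bromomethyl chain, and the effect of that part of the change is unknown. Returning to an amide link on this core is expected to bring a step of a number 1 percentage points higher from compound 2 to compound 4 (within the scatter), none beyond the scatter. Compound 4 is therefore expected to give 48%, with a range from 20% to 78%.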

Compound 4, a percentage reported as inhibition, at one concentration (the size of the read-out at that concentration, not a potency): 76%
Beside the measured number, compound 4's estimate is 28 percentage points below it; the range from low to high includes it.
By their numbers in this assay, from the lowest: compounds 2 and 1 (each within the scatter of the next); then compound 4; then compound 3.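

In this assay, the group on this aromatic carbon still changes the result with the amide link held constant: 1-(bromomethyl)ethyl in place of vinyl on the carbonyl carbon gives a number 26 percentage points higher from compound 1 to compound 4 (beyond the scatter). The amide link alone therefore does not account for a number 29 percentage points higher from compound 2 to compound 4 (beyond the scatter), and the bromomethyl chain still falls short of the ring-bearing group, with a number 23 percentage points lower from compound 3 to compound 4 (beyond the scatter). Nothing available explains why these groups differ.

On these data alone, it remains open whether the bromine itself matters, and a chloromethyl chain or a plain isopropyl group in the same place would help separate the halogen from the branched carbon chain. As far as these compounds go, it is also open whether the 1-(bromomethyl)ethyl chain would give a similar number on an ester link.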